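The source may report more compounds than this note shows. Statements on the series, on what has been measured and on what is new or still open speak of the compounds shown alone.

In an assay for inhibition of 15-hydroxyprostaglandin dehydrogenase [NAD(+)] (Homo sapiens), read by fluorescence, with a stated time of 15 min, in the presence of a further agent that is not named here (a lower number here means a stronger inhibitor, a higher number a weaker inhibitor), compound 2 `CCCC[S+]([O-])c1sc2nc(-c3nccs3)cc(-c3ccc(COC(=O)CN(C)C)cc3)c2c1N` gives 3.5 nM, the second highest of the three numbers seen. Its nearest neighbour is compound 1 `CCCC[S+]([O-])c1sc2nc(-c3ncco3)cc(-c3ccccc3)c2c1N`, which gives 1.4 nM in this assay, a number lower by more than the scatter. Furthest away is compound 3 `CCC[S+]([O-])c1sc2ncccc2c1N`, whose 151 nM in this assay lies well beyond the scatter above compound 2. Among the measured compounds shown here, compound 1 and compound 2 differ in more than one place, so no single step between them can be read.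

Compound 4 `CCCC[S+]([O-])c1sc2nc(-c3nccs3)cc(-c3ccc(CCO)cc3)c2c1N` has not yet been measured. It differs from compound 2 in one place: hydroxymethyl in place of (((dimethylamino)methyl)carbonyl)oxy on a saturated chain carbon bound to an aromatic carbon. The shared core, the sulfinyl chain and the amino group are unchanged. For the measured compounds named here, nothing among the measured compounds tests this particular exchange, so the expected step from compound 2 to compound 4, a 1.4-fold lower number from compound 2 to compound 4 (0.15 log units; within the scatter), is estimated to stay within the scatter, in no firm direction. Compound 4 is therefore expected to give about 2.5 nM in this assay, within a range from 0.8 nM to 8 nM.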

Compound 4, half-maximal inhibitory concentration: 2.9 nM
The estimate for compound 4 lay 1.2-fold (0.06 log units) below the measured number; measured number inside the range.
By their numbers in this assay, from the lowest: compound 1; then compounds 4 and 2 (each within the scatter of the next); then compound 3.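

In this assay, among the compounds shown here, hydroxymethyl in place of (((dimethylamino)methyl)carbonyl)oxy on a saturated chain carbon bound to an aromatic carbon gives a 1.2-fold lower number from compound 2 to compound 4 (0.08 log units; within the scatter), the first reading at this place. A group of 7 heavy atoms with a nitrogen and no hydrogen-bond donor and a group of 2 heavy atoms with 1 hydrogen-bond donor thus give numbers that cannot be told apart here. No measurement shown bears on why these two groups read alike.

The compounds shown leave open whether a carboxylic acid or a primary amine at the end of this chain, or a longer chain, would also stay within the scatter. They also leave open whether the same exchange would read alike with the oxygen-containing ring of compound 1 on the shared core.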